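The compounds below may be only part of what the source reports. "The series", "measured", "known", "first", "only" and "open" are said of these compounds alone.

Compound 1, `O=C(O)[C@@H]1CCCN1C(=O)CN(c1nc(Cl)nc2[nH]cnc12)C1CC1`: 26%
Compound 2, `N=C(N)NCCC[C@H](NC(=O)CN(c1nc(Cl)nc2[nH]cnc12)C1CC1)C(=O)OCc1ccccc1`: 30.4%
Compound 3, `NC(=O)CC[C@H](NC(=O)CN(c1ncnc2c1ncn2C1CCCCO1)C1CC1)C(=O)OCc1ccccc1`: 37.8%

All three compounds were tested in a functional assay on the whole organism (Tail, strain ICR) with Mus musculus as the target, in the tail flick test, with a stated time of 90 min, at a dose of 25 umol/kg by the oral route; a lower number here means a weaker effect, a higher number a stronger effect of the compound at the dose given. Compound 2 sits in the middle of the three numbers, and its gaps to compound 1 and to compound 3 both fall within the usual scatter, so the three measured compounds cannot be told apart on these values.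

Compound 4, `NC(=O)C[C@H](NC(=O)CN(c1nc(Cl)nc2[nH]cnc12)C1CC1)C(=O)OCc1ccccc1`, is not yet measured. It differs from compound 2 in one place: a group of 3 heavy atoms (1 carbon, 1 nitrogen, 1 oxygen; no ring) in place of a group of 6 heavy atoms (3 carbon, 3 nitrogen; no ring), on a saturated chain carbon, two bonds along the chain from an amide-type nitrogen and a carbonyl carbon. Among the compounds with values here, no pair of measured compounds differing in a single place is available, so the numbers give no measured step of this kind to lean on. With all three measured values lying within the scatter of one another, the account expects no step beyond the scatter from compound 2 to compound 4, in either direction. Compound 4 is therefore estimated at 30% in this assay, with a range from 15% to 45%, which means an expected step of a number 0.4 percentage points lower from compound 2 to compound 4 (within the scatter).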

Compound 4, a percentage reported as activity, at one dose (the size of the read-out at that dose, not a potency): 32.3%
The estimate for compound 4 lay 2.3 percentage points below the measured number, and the stated range covers the measured number.
By their numbers in this assay, from the lowest: compounds 1, 2, 4 and 3 (each within the scatter of the next, the first and the last beyond it).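

This gives the first single-place comparison among the compounds shown: in this assay, carbamoyl in place of the group of 6 heavy atoms (3 carbon, 3 nitrogen), on a saturated chain carbon, gives a number 1.9 percentage points higher from compound 2 to compound 4 (within the scatter). At this place, then, the read-out at this dose does not tell the two groups apart, although the group that leaves has 3 hydrogen-bond donors and carbamoyl has 1. Nothing measured here bears on why the two groups give such similar read-outs.

On these data alone, whether a primary amine or a hydroxyl group at this place would move the read-out beyond the scatter remains open. As far as these compounds go, the read-out comes from a single dose and time, so how the two compounds compare in potency also remains open.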